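The source may report more compounds than this note shows. Statements on the series, on what has been measured and on what is new or still open speak of the compounds shown alone.

Working notes on the series.

Two compounds have numbers in an assay on isolated protein for agonist activity at Free fatty acid receptor 1 (Homo sapiens); on this read-out higher numbers stand for an effect only at larger amounts of compound and lower numbers for an effect already at smaller amounts. Compound 1 `CC#CC(CC(=O)O)c1ccc(OCc2ccc3nc(-c4ccc(C(F)(F)F)cc4)cn3c2)cc1` gives 558 nM. Compound 2 `CC#CC(CC(=O)O)c1ccc(OCc2ccn3cc(-c4ccc(C5CCCCC5)cc4)nc3c2)cc1` gives 559 nM. Within the data shown here, compound 2 carries the highest of the two numbers, but the only other value, that of compound 1, lies within the scatter of it, so nothing can be said about an order between compound 1 and compound 2.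

Compound 3 `CC#CC(CC(=O)O)c1ccc(OCc2ccn3cc(-c4ccc(C)cc4)nc3c2)cc1` has not been measured in this assay. It differs from compound 2 in one place: methyl in place of cyclohexyl on an aromatic carbon. Among the measured compounds shown here, no pair of measured compounds shows this change, so the size of the step is not known from data; the two measured compounds do not differ in this group at all.

The expectation for compound 3 is a step toward higher numbers, beyond the scatter, of about a 2.9-fold higher number from compound 2 to compound 3 (0.46 log units; beyond the scatter), since the group that leaves is large and the group that enters is a single carbon. Compound 3 is estimated at 1600 nM, with a range from 500 nM to 5000 nM; the range is wide because the step is not anchored by any measured pair.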

Compound 3, half-maximal effective concentration: 618 nM
Compound 3: middle estimate off by 2.6-fold (0.41 log units), on the high side; measured number inside the range.
By their numbers in this assay, from the lowest: compounds 1, 2 and 3 (each within the scatter of the next).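

In this assay, methyl in place of cyclohexyl on an aromatic carbon gives a 1.1-fold higher number from compound 2 to compound 3 (0.04 log units; within the scatter), so at this position, para to a large group, the two groups cannot be told apart on this read-out. Among these compounds, compound 1 and compound 2 did not differ in this group, which makes this the first direct reading of the exchange. It shows that, on the core shared by compound 2 and compound 3, 4-methylphenyl and 4-cyclohexylphenyl read alike, so the six-membered non-aromatic ring is not required for a number in this range. Nothing measured bears on why the two groups read alike.

The compounds shown leave open whether any group on this aromatic carbon moves the number beyond the scatter, for example a bare hydrogen, a methoxy group, a dimethylamino group or a carboxylic acid. They also leave open whether methyl and cyclohexyl would read alike on the core of compound 1, which here carries trifluoromethyl at the corresponding place.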